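Lengthening the Amine Link in Compound 3

A few compounds are considered here, and "the series" means these few. Any claim that something is new, unique, unknown or untested is made for them only; others in the source may bear on it.

Compound 1, `N#Cc1cnc(NCc2cnccc2C(F)(F)F)cc1N[C@H]1C[C@H](O)C1`, gives 900 nM in an assay on isolated protein for inhibition of protein kinase C theta type (Homo sapiens), read by TR-FRET, with a stated time of 2 h; on this read-out higher numbers stand for weaker inhibition and lower numbers for stronger inhibition.
Compound 2, `N#Cc1cnc(NCc2cnccc2C(F)(F)F)cc1NC[C@H]1C[C@H](O)C1`, gives 700 nM in this assay.
Compound 3, `CO[C@H]1CC[C@H](Nc2cc(NCc3cnccc3C(F)(F)F)ncc2C#N)CC1`, gives 1100 nM in this assay.

Among these three numbers compound 3 carries the highest one, but neither of its two comparisons reaches beyond the scatter: a 1.2-fold higher number from compound 1 to compound 3 (0.09 log units; within the scatter) and a 1.6-fold higher number from compound 2 to compound 3 (0.20 log units; within the scatter). The three compounds therefore cannot be ranked against each other on what has been measured.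

Compound 4, `CO[C@H]1CC[C@H](CNc2cc(NCc3cnccc3C(F)(F)F)ncc2C#N)CC1`, has not yet been measured. It differs from compound 3 in a single place: (4-methoxycyclohexyl)methyl in place of 4-methoxycyclohexyl on a nitrogen on an aromatic ring. Within the data shown here, one measured step bears directly on this change, because it makes the same kind of alteration on the other ring type: a 1.3-fold lower number from compound 1 to compound 2 (0.11 log units; within the scatter). That step stayed within the scatter, so there is no sign from the data shown that moving the ring one bond away from the nitrogen changes the number in this assay by more than ordinary repeat variation.

Compound 4 is therefore expected to land close to compound 3, with the estimated step being a 1.2-fold lower number from compound 3 to compound 4 (0.09 log units; within the scatter). The estimate for compound 4 in this assay is 900 nM, with a range from 400 nM to 2000 nM.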

Compound 4, half-maximal inhibitory concentration: 330 nM
The estimate for compound 4 lay 2.7-fold (0.44 log units) above the measured number, outside the stated range (below it).
By their numbers in this assay, from the lowest: compound 4; then compounds 2, 1 and 3 (each within the scatter of the next).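

The lengthened link behaves differently on the two rings. Among these compounds, on the 4-methoxycyclohexyl group, (4-methoxycyclohexyl)methyl in place of 4-methoxycyclohexyl on a nitrogen on an aromatic ring gives the first step at this position beyond the scatter in this assay (a 3.3-fold lower number from compound 3 to compound 4 (0.52 log units; beyond the scatter)), while the matching change on the 3-hydroxycyclobutyl group stays within it (a 1.3-fold lower number from compound 1 to compound 2 (0.11 log units; within the scatter)). The ring also counts once the link is longer: 4-methoxycyclohexyl in place of 3-hydroxycyclobutyl is beyond the scatter on the lengthened link (a 2.1-fold lower number from compound 2 to compound 4 (0.33 log units; beyond the scatter)) but within it on the shorter link (a 1.2-fold higher number from compound 1 to compound 3 (0.09 log units; within the scatter)), and compound 4 also separates from the remaining comparison (a 2.7-fold lower number from compound 1 to compound 4 (0.44 log units; beyond the scatter)), which makes it the most potent of the four. No evidence is shown that accounts for this dependence on the ring.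

The compounds shown do not separate the contribution of ring size from that of the methoxy group, which (4-hydroxycyclohexyl)methyl would address. They also leave open whether a longer chain between the nitrogen and the ring, or an amine in place of the methoxy group, would keep the lower number of compound 4.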